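The source may hold more compounds than are shown below. What is called first, only, known or untested is meant among the compounds shown, and "the series" means these compounds.

Working notes on the series. In a functional assay on CHO cells for agonist activity at Alpha-1B adrenergic receptor (Homo sapiens), read by FLIPR and calcium flux (on this read-out lower numbers stand for an effect already at smaller amounts and higher numbers for an effect only at larger amounts of compound), compound 1 `CCCS(=O)(=O)Nc1cccc2c1CCC2c1ncc[nH]1` gives > 10000 nM, which is a limit of the assay rather than a number. Compound 2 `CS(=O)(=O)Nc1cccc2c1CCC2c1ncc[nH]1` gives > 10000 nM in this assay, again a limit. Compound 3 `c1cncc(-c2cccc3c2CCC3c2ncc[nH]2)c1` gives > 10000 nM in this assay, also a limit. The steps a step that the two limits leave unreadable from compound 1 to compound 2, a step that the two limits leave unreadable from compound 1 to compound 3 and a step that the two limits leave unreadable from compound 2 to compound 3 carry no readable size. Compound 3 stands at the limit of > 10000 nM in this assay, at which 3 of the 3 values shown sit, with no number of its own to anchor a comparison. Compound 4 `c1cc(-c2nccs2)c2c(c1)C(c1ncc[nH]1)CC2` differs from compound 3 by 1,3-thiazol-2-yl in place of pyridin-3-yl on an aromatic carbon. For the measured compounds named here, the two steps that bear on this position, both leading to compound 3, are unreadable and give neither direction nor size for a change of the aryl group at this carbon; the only guide is that compound 3 sits at the limit. The step of a number no higher from compound 3 to compound 4 (the limit leaves the size open) is expected to be small, with the assay most likely reporting a limit once more. Compound 4 is estimated at 10000 nM in this assay, within a range from 2000 nM to 50000 nM.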

Compound 4, half-maximal effective concentration: > 10000 nM
Compound 4 gave a limit, no number (the forecaster's own chance of this, stated with the estimate: 80%); the middle value sits exactly at the limit.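

Compound 4 gives > 10000 nM in this assay, again a limit and not a number. For the compounds shown here, no step between compound 4 and compound 1, compound 2 or compound 3 can be read. The compounds shown leave open whether any group on this aromatic carbon changes the read-out in this assay, with all values at one limit: the limit of > 10000 nM in this assay, at which 4 of the 4 values shown sit.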